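The source may hold more compounds than are shown below. What is called first, only, known or untested is meant among the compounds shown, and "the series" means these compounds.

Three compounds share one core and differ only in the aryl group attached to it. Compound 1 `O=C(O)CCc1ccc(OCc2nc(-c3ccccc3Cl)no2)cc1`, compound 2 `O=C(O)CCc1ccc(OCc2nc(-c3ccc(F)cc3)no2)cc1` and compound 3 `COc1cccc(-c2noc(COc3ccc(CCC(=O)O)cc3)n2)c1` were measured in a functional assay on CHO cells for agonist activity at Free fatty acid receptor 1 (Homo sapiens), read by FLIPR and calcium flux, in the presence of a further agent that is not named here; on this read-out lower numbers stand for an effect already at smaller amounts and higher numbers for an effect only at larger amounts of compound. Compound 1 gives 1200 nM, compound 2 gives 680 nM and compound 3 gives 2670 nM. Compound 2 carries the lowest number of the three, although a 1.8-fold lower number from compound 1 to compound 2 (0.25 log units; within the scatter) lies within the scatter, whereas a 3.9-fold higher number from compound 2 to compound 3 (0.59 log units; beyond the scatter) and a 2.2-fold higher number from compound 1 to compound 3 (0.35 log units; beyond the scatter) are modest but beyond the scatter.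

Compound 4 `O=C(O)CCc1ccc(OCc2nc(-c3ccc(C(F)(F)F)cc3)no2)cc1` has not yet been measured in this assay. It differs from compound 2 by trifluoromethyl in place of fluoro on an aromatic carbon. Going by the values given here, no measured step replaces one group by another on the same aromatic carbon; the steps that bear on it are exchanges of the whole aryl group, and all of them were modest in size. A modest change is therefore expected here as well, with no clear direction and most likely not beyond the scatter. Compound 4 is expected to give about 550 nM in this assay, within a range from 180 nM to 1700 nM. This estimate corresponds to an expected 1.2-fold lower number from compound 2 to compound 4 (0.09 log units; within the scatter).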

Compound 4, half-maximal effective concentration: 610 nM
Compound 4: the middle estimate sits 1.1-fold (0.04 log units) below what was measured; the range from low to high includes it.
By their numbers in this assay, from the lowest: compounds 4, 2 and 1 (each within the scatter of the next); then compound 3.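

Trifluoromethyl in place of fluoro, on an aromatic carbon para to a large group, gives in this assay a 1.1-fold lower number from compound 2 to compound 4 (0.05 log units; within the scatter). This is the first step shown that exchanges one group for another on the same carbon rather than exchanging the whole aryl group, and it shows that going from one heavy atom to four at this place leaves the number within the scatter. No measurement bears on why the number stays put at this place.

The compounds shown leave open whether a group of another kind on this same carbon, such as an amine or a nitrile, would also leave the number within the scatter. They also leave open whether a longer chain there, such as a butyl group, would do so, or whether the size of the group has a limit at this place.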